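Working notes: 3,5-dichlorophenyl in place of 3-chloro-2-fluorophenyl

A few compounds are considered here, and "the series" means these few. Any claim that something is new, unique, unknown or untested is made for them only; others in the source may bear on it.

Measured in a functional assay on PC-3 cells (Homo sapiens) for antiproliferative activity, read by MTT assay, with a stated time of 48 h; on this read-out higher numbers stand for weaker inhibition and lower numbers for stronger inhibition:
- compound 1 `COc1ccc(/C=C/C(=O)Nc2cc3c(Nc4cc(Cl)cc(Cl)c4)ncnc3s2)cc1`: 450 nM
- compound 2 `O=C(/C=C/c1ccccc1)Nc1cc2c(Nc3cccc(Cl)c3F)ncnc2s1`: 400 nM

Compound 2 stands level with compound 1 within the scatter, so these two numbers give no ranking. The next compound is compound 3 `O=C(/C=C/c1ccccc1)Nc1cc2c(Nc3cc(Cl)cc(Cl)c3)ncnc2s1`, still unmeasured in this assay. It differs from compound 2 by 3,5-dichlorophenyl in place of 3-chloro-2-fluorophenyl on a nitrogen on an aromatic ring, with 3,5-dichlorophenyl in place of 3-chloro-2-fluorophenyl on a nitrogen on an aromatic ring. Among the compounds with values here, no measured pair isolates this change. Within the data shown here, the only guide is that compound 1, which also carries 3,5-dichlorophenyl on that nitrogen, gives 450 nM. No step beyond the scatter is therefore expected, in either direction. The expected size is a 1.1-fold higher number from compound 2 to compound 3 (0.02 log units; within the scatter). For compound 3 the estimated value is 420 nM, with an expected range of 200 nM to 900 nM.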

Compound 3, half-maximal inhibitory concentration: 390 nM
Beside the measured number, compound 3's estimate is 1.1-fold (0.03 log units) above it, within the range that was stated.
By their numbers in this assay, from the lowest: compounds 3, 2 and 1 (each within the scatter of the next).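

In this assay, 3,5-dichlorophenyl in place of 3-chloro-2-fluorophenyl on a nitrogen on an aromatic ring gives a 1.0-fold lower number from compound 2 to compound 3 (0.01 log units; within the scatter) and thus isolates this swap in a single pair, with the two groups level within the scatter. Compound 3 also provides a pair for the other end of the series: hydrogen in place of methoxy on an aromatic carbon gives a 1.2-fold lower number from compound 1 to compound 3 (0.06 log units; within the scatter) and is likewise within the scatter. No measurement at hand offers an explanation for either step.

Still open, as far as these compounds go, is whether an unsubstituted phenyl or a pyridyl on that nitrogen would give a step beyond the scatter. The same question stands for an amine or a carboxylic acid in place of methoxy on that aromatic carbon.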